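A few compounds are considered here, and "the series" means these few. Any claim that something is new, unique, unknown or untested is made for them only; others in the source may bear on it.

In a functional assay on HL-60 cells (Homo sapiens) for inhibition (a higher number here means a weaker inhibitor, a lower number a stronger inhibitor), compound 1 `COc1ccc(-c2ccccc2-c2cc(OC)c(OC)c(OC)c2)cc1O` gives 20000 nM and compound 2 `COc1ccc(-c2cc(Cl)cnc2-c2cc(OC)c(OC)c(OC)c2)cc1O` gives 500 nM as its reading. Compound 2 therefore holds the lower of the two numbers, and the gap lies well beyond the ordinary scatter of repeat measurements, which makes it the stronger inhibitor of this pair.

The next molecule is compound 3 `COc1ccc(-c2cccnc2-c2cc(OC)c(OC)c(OC)c2)cc1O`, which comes from compound 2 through one small edit. That edit is hydrogen in place of chloro on an aromatic carbon in counted terms, or in words, hydrogen in place of chloro on an aromatic carbon.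

Among the measured compounds shown here, no measured pair here shows this change on its own, so its size has no direct precedent. A moderate step towards a higher number, probably beyond the scatter, seems the likeliest outcome. This guess is bounded by the span of the two measured values, with compound 1 at 20000 nM as the weak end. The estimated change is a 4.0-fold higher number from compound 2 to compound 3 (0.60 log units; beyond the scatter) in size. For compound 3 the expected value is 2000 nM with an estimated range from 500 nM to 10000 nM in this assay.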

Compound 3, half-maximal inhibitory concentration: 300 nM
Compound 3: the middle estimate sits 6.7-fold (0.82 log units) above what was measured, and the stated range ends above it.
By their numbers in this assay, from the lowest: compounds 3 and 2 (each within the scatter of the next); then compound 1.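

In this assay, putting hydrogen in place of chloro on this aromatic carbon, two atoms from the ring nitrogen, gives a 1.7-fold lower number from compound 2 to compound 3 (0.22 log units; within the scatter) and so leaves the two compounds indistinguishable in this assay. The chloro is therefore not required for a reading far from that of compound 1: compound 3, which carries no chloro, gives 300 nM. Compound 3 has its ring nitrogen where compound 1 has a carbon, and in the same test compound 1 gives 20000 nM. No separate measurement is available to explain why this swap leaves the reading within the usual scatter.

The compounds shown cover only chloro and hydrogen at this position, so it stays open how an amine, a carboxylic acid or a longer chain such as propyl would read there. Among the compounds shown here, the ring nitrogen is the one place where compound 1 and compound 3 differ, but a single pair of values cannot show whether the same gap would appear with other groups elsewhere on the core.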